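From a cyclohexyl to a hydroxymethyl-bearing side chain

This account rests on a few compounds, and the source may have more. Where it says the series, first, only, none or still open, it means among the compounds named here.

Within the data shown here, the shared core carries an acyl group on its ring nitrogen, and the three measured members differ in that group and in the aryl ring. In an ADME assay on microsomes (Rattus norvegicus) for metabolic stability (on this read-out lower numbers stand for a shorter-lived compound and higher numbers for a longer-lived compound), compound 1 `O=C(C1CCCCC1)N1N=CCC1c1ccccc1` gives 0.0833 h, which places it second highest among the three numbers. Compound 3 `Cc1ccc(C2CC=NN2C(=O)C(C)(C)C)cc1` gives 0.0383 h in this assay, a shorter half-life than compound 1 and beyond the usual scatter. Compound 2 `N#Cc1cc(N2CCC(C(=O)N3N=CC[C@H]3c3cc(F)cc(F)c3)CC2)ncn1` gives 1.15 h in this assay, a much longer half-life than compound 1 and far beyond the scatter.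

Compound 4 `CC(C)(CO)C(=O)N1N=CCC1c1ccccc1`, still to be measured in this assay, differs from compound 1 in one place: 1-(hydroxymethyl)-1-methylethyl in place of cyclohexyl on a carbonyl carbon. Among the measured compounds shown here, no step between measured compounds covers this change, so the expectation rests on the spread of the three values. Compound 4 is expected to show a step of a 1.8-fold higher number from compound 1 to compound 4 (0.26 log units; within the scatter) that stays within the scatter, leaning slightly upward, because compound 3 with its saturated acyl group gives 0.0383 h while compound 2 with polar groups gives 1.15 h. Compound 4 is therefore estimated at 0.15 h in this assay, with a plausible range from 0.05 h to 0.5 h.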

Compound 4, half-life: 0.917 h
The estimate for compound 4 lay 6.1-fold (0.79 log units) below the measured number; the measured number lies above the stated range.
By their numbers in this assay, from the lowest: compound 3; then compound 1; then compounds 4 and 2 (each within the scatter of the next).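

In this assay, among these compounds, putting 1-(hydroxymethyl)-1-methylethyl in place of cyclohexyl on a carbonyl carbon gives an 11-fold higher number from compound 1 to compound 4 (1.04 log units; beyond the scatter), a large step that shows the half-life responds strongly to this acyl group alone, with the aryl ring unchanged, which the earlier compounds, differing from one another in more than one place, could not show. The change is not a single one, however: the entering group has 5 heavy atoms against 6, no ring, and 1 hydrogen-bond donor and 1 hydrogen-bond acceptor where cyclohexyl has none, so this one step cannot tell these differences apart. No measurement shown here accounts for the size of the step.

The compounds shown leave open whether the hydroxyl group, the removal of the ring or the branched carbon chain carries the step. A methyl ether in place of the hydroxyl, a carboxylic acid or an amine at the end of the chain, or a longer chain bearing the hydroxyl would each probe a different part of that question, and whether the same change holds with other aryl rings also remains undecided.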